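Chalcone-to-amide series: methoxy addition on the methoxyphenyl ring

This account rests on a few compounds, and the source may have more. Where it says the series, first, only, none or still open, it means among the compounds named here.

Measured compounds:
compound 1 `COc1ccc(/C=C/C(=O)c2ccccc2-c2cccc(F)c2)cc1`: 640 nM
compound 2 `COc1ccc(/C=C/C(=O)c2ccccc2-c2cccc(F)c2)cc1OC`: 1200 nM
compound 3 `COc1ccc(CNC(=O)c2ccccc2-c2ccc(F)cc2)cc1`: > 50000 nM

In a functional assay on MCF7 cells (Homo sapiens) for antiproliferative activity, read by sulforhodamine B assay, with a stated time of 48 h (on this read-out higher numbers stand for weaker inhibition and lower numbers for stronger inhibition), compound 1 gives 640 nM and compound 2 gives 1200 nM. The change between them, (methoxy in place of hydrogen on an aromatic carbon), produced a 1.9-fold higher number from compound 1 to compound 2 (0.27 log units; within the scatter). Compound 3 carries a different core, and how its core differs from that of compound 1 is not broken down here. For compound 3 this assay returns only a limit, > 50000 nM; it is one of the values described by the limit of > 50000 nM in this assay, at which 1 of the 3 values shown sits.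

Compound 4 `COc1ccc(CNC(=O)c2ccccc2-c2ccc(F)cc2)cc1OC` is not yet measured. For the measured compounds named here, it differs from compound 3 by methoxy in place of hydrogen on an aromatic carbon, the same change as the one from compound 1 to compound 2, since the place lines for both read alike. That earlier step sat within the scatter, which gives no reason to expect the methoxy to lift the core of compound 3 off its limit.

The expectation for compound 4 rests on compound 3 sitting at the limit > 50000 nM and on the step of a 1.9-fold higher number from compound 1 to compound 2 (0.27 log units; within the scatter) being within the scatter. The step from compound 3 to compound 4 is therefore estimated as a step that the limit leaves unreadable from compound 3 to compound 4. For compound 4 in this assay the estimate is 60000 nM, with an expected range from 30000 nM to 200000 nM, and it is expected that the assay will most likely again report only a limit.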

Compound 4, half-maximal inhibitory concentration: > 50000 nM
Compound 4 ended at the assay's limit; the forecaster's own chance of this, stated with the estimate: 85%; the middle value does not contradict the limit.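

No step can be read from compound 3 to compound 4, since both values are limits and neither is a number: the limit of > 50000 nM in this assay, at which 2 of the 4 values shown sit.

The compounds shown leave open whether methoxy in place of hydrogen on an aromatic carbon shifts the number on the core of compound 3 at all, and which structural difference between that core and the core of compound 1 separates their values.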